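Methoxy in place of methoxycarbonyl: compound 3

The source may report more compounds than this note shows. Statements on the series, on what has been measured and on what is new or still open speak of the compounds shown alone.

Measured compounds:
compound 1 `Cc1ccc(S(=O)(=O)OCCCc2cn(-c3ccc(C(F)(F)F)cc3)nn2)cc1`: > 100000 nM
compound 2 `COC(=O)c1ccc(-n2cc(CCCOS(=O)(=O)c3ccc(C)cc3)nn2)cc1`: > 100000 nM

In a functional assay on MDA-MB-231 cells (Homo sapiens) for cytotoxicity, read by MTT assay, with a stated time of 48 h (a lower number here means a stronger inhibitor, a higher number a weaker inhibitor), compound 2 gives > 100000 nM, and this is a limit of the assay, not a number. Compound 1 gives > 100000 nM, which is also a limit. All the measured data therefore sit together: the limit of > 100000 nM in this assay, at which 2 of the 2 values shown sit.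

Compound 3 `COc1ccc(-n2cc(CCCOS(=O)(=O)c3ccc(C)cc3)nn2)cc1` departs from compound 2 at one place: methoxy in place of methoxycarbonyl on an aromatic carbon. This is methoxy in place of methoxycarbonyl on an aromatic carbon, para to a large group.

Going by the values given here, only one measured step bears on this change, as it alters the same group: a step that the two limits leave unreadable from compound 1 to compound 2, with methoxycarbonyl in place of trifluoromethyl on an aromatic carbon. It gives no size to carry over and no direction. Among the compounds with values here, no measured compound carries a number in this assay, so no step beyond the scatter is expected, in either direction. The expected result is a number no higher from compound 2 to compound 3 (the limit leaves the size open), and another report of a limit alone is the likeliest outcome. Compound 3 is estimated at 100000 nM, with an expected range from 30000 nM to 300000 nM.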

Compound 3, half-maximal inhibitory concentration: 72800 nM
Compound 3: the middle estimate sits 1.4-fold (0.14 log units) above what was measured; the range from low to high includes it.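

In this assay, going by these compounds alone, compound 3, with methoxy on the aromatic carbon para to a large group, is the first compound here to give a number, 72800 nM, rather than a limit of the assay. Methoxy in place of methoxycarbonyl gives an at least 1.3-fold lower number from compound 2 to compound 3 (0.13 log units; that floor lies within the scatter), and methoxy in place of trifluoromethyl gives an at least 1.3-fold lower number from compound 1 to compound 3 (0.13 log units; that floor lies within the scatter); each is only a floor, so neither establishes a step beyond the scatter, although the true size of either could be larger. This position can therefore carry a group that returns a readable value, while the other two groups at the same place remain unresolved: the limit of > 100000 nM in this assay, at which 2 of the 3 values shown sit.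

As far as these compounds go, how far compound 1 and compound 2 really lie from compound 3 stays open, so the data give only a lower bound on the effect of replacing either group with methoxy. Also open, from the compounds shown here alone, is whether an amine, a hydroxyl group or a longer alkoxy chain at this place would give a readable value, and how any such value would compare with that of compound 3.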